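Ring-Closed Ester Urea in the Vasopressin V2 Series

The source may report more compounds than this note shows. Statements on the series, on what has been measured and on what is new or still open speak of the compounds shown alone.

Compound 3 `Cc1cc(C(=O)N2CCCCc3ccccc32)ccc1CNC(=O)NCC(=O)N(C)C` gives 58 nM in a functional assay on HEK293 cells for agonist activity at Vasopressin V2 receptor (Homo sapiens), read by a luciferase reporter and cAMP accumulation (on this read-out higher numbers stand for an effect only at larger amounts of compound and lower numbers for an effect already at smaller amounts), the highest of the three numbers; compound 2 `COC(=O)CNC(=O)NCc1ccc(C(=O)N2CCCCc3ccccc32)cc1C` gives 37 nM, within the scatter of that, whereas compound 1 `Cc1cc(C(=O)N2CCCCc3ccccc32)ccc1CNC(=O)Nc1c(F)cccc1F` gives 2.1 nM, beyond it. Compound 4 `COC(=O)[C@@H]1CCCN1C(=O)NCc1ccc(C(=O)N2CCCCc3ccccc32)cc1C` differs from compound 3 by 2-(methoxycarbonyl)pyrrolidin-1-yl in place of ((dimethylcarbamoyl)methyl)amino on a carbonyl carbon. Among the compounds with values here, three steps bear on this. Replacing the aryl group on the urea nitrogen, an 18-fold higher number from compound 1 to compound 2 (1.25 log units; beyond the scatter) and a 28-fold higher number from compound 1 to compound 3 (1.44 log units; beyond the scatter), placed both open-chain carbonyl substituents well above compound 1. The exchange a 1.6-fold higher number from compound 2 to compound 3 (0.20 log units; within the scatter) showed methoxy and dimethylamino on that carbonyl carbon to be indistinguishable. Since compound 4 retains an ester, the step of a 1.5-fold lower number from compound 3 to compound 4 (0.16 log units; within the scatter) is expected to stay within the scatter. Compound 4 is therefore estimated at 40 nM, between 10 nM and 160 nM.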

Compound 4, half-maximal effective concentration: 100 nM
Compound 4: middle estimate off by 2.5-fold (0.40 log units), on the low side; measured number inside the range.
By their numbers in this assay, from the lowest: compound 1; then compounds 2, 3 and 4 (each within the scatter of the next, the first and the last beyond it).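

Within the data shown here, with the ester kept, 2-(methoxycarbonyl)pyrrolidin-1-yl in place of ((methoxycarbonyl)methyl)amino on the carbonyl carbon gives the first step among the non-aryl groups to pass the scatter (a 2.7-fold higher number from compound 2 to compound 4 (0.43 log units; beyond the scatter)), while the change from the dimethylcarbamoyl chain stays inside it (a 1.7-fold higher number from compound 3 to compound 4 (0.24 log units; within the scatter)). Compound 4 also shows the widest gap to the 2,6-difluorophenyl urea (a 48-fold higher number from compound 1 to compound 4 (1.68 log units; beyond the scatter)). Nothing measured here accounts for these steps. Open remain a pyrrolidine carrying a carboxylic acid or dimethylcarbamoyl instead of methoxycarbonyl, and the opposite configuration at the stereocentre. The ring's contribution therefore cannot yet be separated from that of the ester.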